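Replacing the aminocyclohexyl amide with a pyrrolidinyl amide

The source may hold more compounds than are shown below. What is called first, only, known or untested is meant among the compounds shown, and "the series" means these compounds.

Measured compounds:
Compound 1 `CC(C)N[C@H](C(=O)Nc1cc2cc[nH]c(=O)c2cc1Cl)C1CCCCC1`: 25 nM
Compound 2 `N[C@H]1CC[C@H](C(=O)Nc2cc3cc[nH]c(=O)c3cc2Cl)CC1`: 330 nM
Compound 3 `CC(C)(C)C[C@H](N)C(=O)Nc1cc2cc[nH]c(=O)c2cc1Cl`: 845 nM

The three measured compounds share one core and differ only in the group on the carbonyl carbon of the amide. In an assay on isolated protein for inhibition of Rho-associated protein kinase 2 (Homo sapiens) (a higher number here means a weaker inhibitor, a lower number a stronger inhibitor), compound 1 gives 25 nM. Compound 2 stands second highest of the three numbers; its nearest neighbour is compound 3, which lies a modest step higher, while compound 1 lies furthest away with a markedly lower number.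

The unmeasured compound 4 `O=C(Nc1cc2cc[nH]c(=O)c2cc1Cl)[C@H]1CCCN1` is derived from compound 2 by a single change: pyrrolidin-2-yl in place of 4-aminocyclohexyl on a carbonyl carbon. For the measured compounds named here, the one measured step that bears on this is the exchange of the same group in compound 2 for a different amine-bearing group in compound 3, which gave a 2.6-fold higher number from compound 2 to compound 3 (0.41 log units; beyond the scatter). That step shows that altering the group on the carbonyl carbon away from the 4-aminocyclohexyl of compound 2 can raise the number beyond the scatter, though it involves a different entering group, so it sets only a loose guide. A step of comparable size and direction is therefore expected for compound 4 in this assay, a 1.8-fold higher number from compound 2 to compound 4 (0.26 log units; within the scatter), with a wide range to allow for the untested group. Compound 4 is estimated at 600 nM, within roughly 200 nM to 1800 nM.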

Compound 4, half-maximal inhibitory concentration: 130 nM
For compound 4 the middle estimate is 4.6-fold (0.66 log units) above the measured one; measured number outside the range, below it.
By their numbers in this assay, from the lowest: compound 1; then compound 4; then compound 2; then compound 3.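

In this assay the earlier step had shown only a rise in the number on leaving 4-aminocyclohexyl, but pyrrolidin-2-yl on the same carbonyl carbon moves it the other way, with a 2.5-fold lower number from compound 2 to compound 4 (0.40 log units; beyond the scatter) as the result of the exchange. The same group also improves on 1-amino-3,3-dimethylbutyl, with a 6.5-fold lower number from compound 3 to compound 4 (0.81 log units; beyond the scatter) in this comparison, so among these compounds a change at this position can shift the number in either direction, and the entering group with fewer heavy atoms and a five-membered ring gives the lower number in both comparisons. The counts of atoms and rings describe this change, but nothing in the data given accounts for the gain.

The compounds shown leave open whether the gain follows from the size of the ring or from the nitrogen standing within it, as none of them carries an azetidin-2-yl or piperidin-2-yl group on the carbonyl carbon. They also leave open how the pyrrolidin-2-yl amide would respond to an isopropyl group on its ring nitrogen or to the opposite configuration at its stereocentre.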